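A Bridged Ring Replaces the Open Dipropylamino Chain

The source may hold more compounds than are shown below. What is called first, only, known or untested is meant among the compounds shown, and "the series" means these compounds.

Three compounds have been measured in an assay on isolated protein for displacement of a labelled ligand from melanin-concentrating hormone receptor 1 (Homo sapiens); a higher number here means a weaker inhibitor, a lower number a stronger inhibitor:
compound 1, `CCCN(CCC)c1ccc2cc(NC(=O)CCc3ccc(C(F)(F)F)cc3)ccc2n1`: 490 nM
compound 2, `CC(=O)NC1CCN(c2ccc3cc(NC(=O)CCc4ccc(C(F)(F)F)cc4)ccc3n2)C1`: 5 nM
compound 3, `CCN(CC)c1ccc2cc(NC(=O)CCc3ccc(C(F)(F)F)cc3)ccc2n1`: 88 nM

Compound 1 gives the highest number of the three, so it is the weakest inhibitor shown. Shrinking its dipropylamino to diethylamino gives a 5.6-fold lower number from compound 1 to compound 3 (0.75 log units; beyond the scatter), a modest gain. Replacing it with 3-acetamidopyrrolidin-1-yl gives a 98-fold lower number from compound 1 to compound 2 (1.99 log units; beyond the scatter), by far the largest change in the set.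

Compound 4, `O=C(CCc1ccc(C(F)(F)F)cc1)Nc1ccc2nc(N3CC4CCC3C4)ccc2c1`, has not been measured yet. Compared with compound 1 its change is a group of 7 heavy atoms (6 carbon, 1 nitrogen; one five-membered non-aromatic ring of carbon only, one five-membered non-aromatic ring with 1 hetero atom) in place of a group of 7 heavy atoms (6 carbon, 1 nitrogen; no ring), on an aromatic carbon. Both earlier steps bear on it: each replaced dipropylamino on the same aromatic carbon and each lowered the number, and the one that brought in a ring lowered it most. The new group is also a ring system, though it carries no hydrogen-bond donor as the 3-acetamidopyrrolidin-1-yl of compound 2 does, so a step smaller than that of compound 2 but larger than that of compound 3 seems the most likely outcome.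

For compound 4 the expected step is therefore a 12-fold lower number from compound 1 to compound 4 (1.09 log units; beyond the scatter), downward and beyond the scatter. The estimate for compound 4 in this assay is 40 nM, with a likely range from 10 nM to 160 nM.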

Compound 4, half-maximal inhibitory concentration: 1 nM
Compound 4: the middle estimate sits 40-fold (1.60 log units) above what was measured; measured number outside the range, below it.
By their numbers in this assay, from the lowest: compound 4; then compound 2; then compound 3; then compound 1.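

The group that enters matches dipropylamino in its 7 heavy atoms and its counts of hydrogen-bond donors and acceptors, yet in this assay it gives a 490-fold lower number from compound 1 to compound 4 (2.69 log units; beyond the scatter) at this position next to the ring nitrogen, so joining the same kinds of atoms into rings changes the number far more than these counts would suggest. Compound 2 left open whether the hydrogen-bond donor of its 3-acetamidopyrrolidin-1-yl was needed for a low number, but compound 4 has no donor and still shows a 5.0-fold lower number from compound 2 to compound 4 (0.70 log units; beyond the scatter) in this series. Group size alone does not order these compounds either: the ring system has more heavy atoms than diethylamino and gives an 88-fold lower number from compound 3 to compound 4 (1.94 log units; beyond the scatter) as the number falls further. No measurement shown here explains why the ring system has this effect.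

The compounds shown leave open whether the bridge itself matters or a single ring would serve as well, a question that plain pyrrolidin-1-yl or piperidin-1-yl at this position could address. They also leave open whether an acetamido group on the bridged ring would lower the number further or raise it.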